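The source may hold more compounds than are shown below. What is called first, only, known or untested is meant among the compounds shown, and "the series" means these compounds.

Compound 1 `CCCOC(=O)CCC(=O)N1CCN(CCCOc2cc3c(Nc4ccc(F)c(Cl)c4)ncnc3cc2OC)CC1` carries the shortest ester chain of this set; in a functional assay on A549 cells (Homo sapiens) for cytotoxicity, read by MTT assay, with a stated time of 24 h, tested at 80 uM (on this read-out higher numbers stand for a weaker effect at the one concentration tested and lower numbers for a stronger effect), compound 1 gives 23.4%. Compound 2 `CCCCOC(=O)CCC(=O)N1CCN(CCCOc2cc3c(Nc4ccc(F)c(Cl)c4)ncnc3cc2OC)CC1` differs from it by methyl in place of hydrogen on a saturated chain carbon, three bonds along the chain from an oxygen next to a carbonyl group, and compound 2 gives 36.9%, so that a number 13.5 percentage points higher from compound 1 to compound 2 (beyond the scatter). Compound 3 `CCCCCCCCCCCCCCCOC(=O)CCC(=O)N1CCN(CCCOc2cc3c(Nc4ccc(F)c(Cl)c4)ncnc3cc2OC)CC1` differs from compound 1 by dodecyl in place of hydrogen on a saturated chain carbon, three bonds along the chain from an oxygen next to a carbonyl group; compound 3 gives 81.1%, with a number 57.7 percentage points higher from compound 1 to compound 3 (beyond the scatter) and a number 44.2 percentage points higher from compound 2 to compound 3 (beyond the scatter). Within these three compounds every lengthening of the ester chain has raised the number, and compound 3 stands highest, beyond the scatter of both others.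

Compound 4 `CCCCCCCCCCCCCCCCOC(=O)CCC(=O)N1CCN(CCCOc2cc3c(Nc4ccc(F)c(Cl)c4)ncnc3cc2OC)CC1` is not yet measured; it differs from compound 3 by methyl in place of hydrogen on a saturated chain carbon, ten or more bonds along the chain from an oxygen next to a carbonyl group. This is the same kind of change as that from compound 1 to compound 2, but the place differs: here the new carbon sits farther along the chain from the oxygen next to a carbonyl group than it did there. For compound 4 the expected step is small, a number 2.9 percentage points higher from compound 3 to compound 4 (within the scatter), since compound 3 already stands at 81.1% and the earlier step of a number 13.5 percentage points higher from compound 1 to compound 2 (beyond the scatter) was only modest. The estimate for compound 4 is 84%, between 72% and 95%.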

Compound 4, a percentage reported as activity, at one concentration (the size of the read-out at that concentration, not a potency): 74.3%
Beside the measured number, compound 4's estimate is 9.7 percentage points above it, and the stated range covers the measured number.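

Among these compounds, the new step, a number 6.8 percentage points lower from compound 3 to compound 4 (within the scatter), shows that in this assay the methyl change does not carry over from the short ester chain to the long one, and the two results differ: the same change on two cores in this assay, a number 13.5 percentage points higher (beyond the scatter) from compound 1 to compound 2 and a number 6.8 percentage points lower (within the scatter) from compound 3 to compound 4, 20.3 percentage points apart, beyond the scatter of two such steps The dodecyl change keeps its direction when moved from one core to another, since a number 37.4 percentage points higher from compound 2 to compound 4 (beyond the scatter), but its size does not carry over unchanged: the same change on two cores in this assay, a number 57.7 percentage points higher (beyond the scatter) from compound 1 to compound 3 and a number 37.4 percentage points higher (beyond the scatter) from compound 2 to compound 4, 20.3 percentage points apart, beyond the scatter of two such steps These are only two pairs for each change, and the new carbon sits at a different place along the chain in each pair, so the data do not show whether that place or the rest of the core sets the size of a step, nor do they give a rule for other chains.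

The compounds shown leave open how an ester chain of intermediate length, or a still longer chain, would read in this assay. They also leave open whether a branched chain, or an amine or a carboxylic acid at the chain end, would follow the same trend.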